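A Chloromethyl Group Takes the Place of an Aryl Amide

A few compounds are considered here, and "the series" means these few. Any claim that something is new, unique, unknown or untested is made for them only; others in the source may bear on it.

Of the compounds shown here, three sharing one core have been tested in a functional assay on A875 cells (Homo sapiens) for antiproliferative activity, read by MTT assay, with a stated time of 48 h; on this read-out lower numbers stand for stronger inhibition and higher numbers for weaker inhibition. Compound 1 `O=C(CSc1nnc(NC(=O)c2c(Cl)cccc2Cl)s1)Nc1ccc(Br)cn1` gives 18600 nM in this assay. For compound 2 `COc1ccccc1C(=O)Nc1nnc(SCC(=O)Nc2ccc(Br)cn2)s1` this assay reports only a limit, > 80000 nM. For compound 3 `COc1ccccc1C(=O)Nc1nnc(SCC(=O)Nc2c(C)ccnc2Cl)s1` this assay likewise reports only a limit, > 80000 nM. The step of an at least 4.3-fold higher number from compound 1 to compound 2 (0.63 log units; beyond the scatter) shows that the 2-methoxyphenyl group pushed the number upward, whereas the step that the two limits leave unreadable from compound 2 to compound 3 cannot be sized, since both of its values sit at the limit of > 80000 nM in this assay, at which 2 of the 3 values shown sit. Compound 2 thus stands at the limit of this assay, with no number of its own.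

Compound 4 `O=C(CSc1nnc(NC(=O)CCl)s1)Nc1ccc(Br)cn1` differs from compound 2 by chloromethyl in place of 2-methoxyphenyl on a carbonyl carbon. Going by the values given here, only the step from compound 1 to compound 2 concerns this carbonyl carbon, and it ran toward weaker inhibition; no measured step shows what a chloromethyl group does here. Compound 4 is therefore expected to remain weak in this assay, estimated at 70000 nM within a range of 15000 nM to 200000 nM. The step of an at least 1.1-fold lower number from compound 2 to compound 4 (0.05 log units; that floor lies within the scatter) is expected to stay within the scatter.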

Compound 4, half-maximal inhibitory concentration: 13900 nM
Compound 4: the middle estimate sits 5.0-fold (0.70 log units) above what was measured; the measured number lies below the stated range.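

On this carbonyl carbon, a ring is not needed for a measurable number in this assay, since chloromethyl, which has no ring, gives an at least 5.7-fold lower number from compound 2 to compound 4 (0.76 log units; beyond the scatter) and so separates clearly from 2-methoxyphenyl. Set against 2,6-dichlorophenyl, the same group gives a 1.3-fold lower number from compound 1 to compound 4 (0.13 log units; within the scatter), which leaves these two very different groups indistinguishable in this assay. The first step can be read only as a floor, because compound 2 has a limit and no number of its own: the limit of > 80000 nM in this assay, at which 2 of the 4 values shown sit.

From the compounds shown here alone, what a plain methyl group or a longer chain such as 3-chloropropyl would give on this carbonyl carbon remains open, and so does whether the chlorine of chloromethyl matters at all. Also open, going by these compounds, is whether chloromethyl would hold its number with 2-chloro-4-methylpyridin-3-yl on the amide-type nitrogen.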